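Triazole ether series: cyano to methyl on the aryloxy ring

The compounds below may be only part of what the source reports. "The series", "measured", "known", "first", "only" and "open" are said of these compounds alone.

In an assay on isolated protein for inhibition of Aromatase (Homo sapiens), read by fluorescence and colorimetric assay, with a stated time of 30 min (on this read-out lower numbers stand for stronger inhibition and higher numbers for weaker inhibition), compound 2 `N#Cc1ccc(Cn2cc(COc3ccc(C#N)cc3)nn2)cc1` gives 9160 nM, the lower of the two numbers shown, though the gap to compound 1 `Cc1ccc(OCc2cn(C(c3ccc(C#N)cc3)c3ccc(C#N)cc3)nn2)cc1` is within the scatter, as compound 1 gives 11000 nM in this assay. Compound 3 `Cc1ccc(OCc2cn(Cc3ccc(C#N)cc3)nn2)cc1` differs from compound 2 by methyl in place of cyano on an aromatic carbon. Going by the values given here, no step between measured compounds covers this change; since compound 1, which already carries the methylphenyl ether, gives 11000 nM, no step beyond the scatter is expected in either direction. Compound 3 is therefore estimated at 10000 nM, in the range 3500 nM to 30000 nM. The expected step is a 1.1-fold higher number from compound 2 to compound 3 (0.04 log units; within the scatter), inside the scatter.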

Compound 3, half-maximal inhibitory concentration: 4170 nM
Compound 3: the middle estimate sits 2.4-fold (0.38 log units) above what was measured, and the stated range covers the measured number.
By their numbers in this assay, from the lowest: compound 3; then compounds 2 and 1 (each within the scatter of the next).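

Methyl in place of cyano on an aromatic carbon, para to a large group, gives a 2.2-fold lower number from compound 2 to compound 3 (0.34 log units; beyond the scatter) in this assay, so this position responds to the change by more than the scatter. Compound 1 and compound 3 share the methylphenyl ether, and hydrogen in place of 4-cyanophenyl on the saturated chain carbon gives a 2.6-fold lower number from compound 1 to compound 3 (0.42 log units; beyond the scatter), so the methyl step may not hold with that second 4-cyanophenyl present. No measurement shown accounts for either step.

On these data alone, whether an amine, a methoxy group or a chlorine at this position would give a lower number remains open.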